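A few compounds are considered here, and "the series" means these few. Any claim that something is new, unique, unknown or untested is made for them only; others in the source may bear on it.

Of the compounds shown here, three with the shared core have been measured in a functional assay on MCF7 cells (Homo sapiens) for cytotoxicity, read by MTT assay, with a stated time of 48 h; on this read-out higher numbers stand for weaker inhibition and lower numbers for stronger inhibition. Compound 1 `S=C(N/N=C\c1ccnc2ccccc12)Nc1cccnc1` gives 970 nM, compound 2 `Fc1ccc(NC(=S)N/N=C\c2ccnc3ccccc23)cc1` gives 1100 nM and compound 3 `S=C(N/N=C\c1ccnc2ccccc12)Nc1ccc(Br)cc1` gives 990 nM. Compound 3 therefore stands level with the other two, within the scatter of both.

The next structure is compound 4 `C=CCNC(=S)N/N=C\c1ccnc2ccccc12`, and the change is allyl in place of 4-bromophenyl on an amide-type nitrogen. Allyl takes the place of 4-bromophenyl on an amide-type nitrogen whose other neighbour is the thiocarbonyl carbon.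

Among the measured compounds shown here, three measured steps bear on this change: a 1.0-fold higher number from compound 1 to compound 3 (0.01 log units; within the scatter), a 1.1-fold higher number from compound 1 to compound 2 (0.05 log units; within the scatter) and a 1.1-fold lower number from compound 2 to compound 3 (0.05 log units; within the scatter). All three lie within the scatter, so the aromatic groups tried on that nitrogen make no visible difference. None of these steps replaces the aromatic group with a chain, so the data do not cover the move to allyl directly.

The flatness of these steps argues against a large change, but the untested type of group calls for a wide range. The expected result in this assay is a small move towards weaker inhibition, with an estimated 1.6-fold higher number from compound 3 to compound 4 (0.21 log units; within the scatter). For compound 4 the estimated value is 1600 nM, with an expected range of 650 nM to 4500 nM.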

Compound 4, half-maximal inhibitory concentration: 970 nM
Compound 4: the middle estimate sits 1.6-fold (0.22 log units) above what was measured, within the range that was stated.
By their numbers in this assay, from the lowest: compounds 1, 4, 3 and 2 (each within the scatter of the next).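

Replacing the aromatic group with a chain on the amide-type nitrogen leaves the number level in this assay (a 1.0-fold lower number from compound 3 to compound 4 (0.01 log units; within the scatter)), and the same holds against the other two aromatic groups (a 1.1-fold lower number from compound 2 to compound 4 (0.05 log units; within the scatter)) (no change at the digits printed from compound 1 to compound 4 (within the scatter)). The earlier steps only exchanged one six-membered aromatic ring for another, whereas allyl has no ring and 3 heavy atoms against the 7 of 4-bromophenyl, so among these four compounds an aromatic ring at this place is not needed to keep the number at this level. Nothing available accounts for this flat result.

From the compounds shown here alone, whether the flatness extends to other kinds of group on this nitrogen remains open, for instance a saturated propyl group, a longer chain, an amine or a carboxylic acid. It is also open whether the number responds to a change elsewhere in the shared core, such as a carbonyl in place of the thiocarbonyl, which would show if any part of these compounds moves this read-out.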